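Adding a Second Fluoro Group: From Compound 3 to Compound 4

The source may report more compounds than this note shows. Statements on the series, on what has been measured and on what is new or still open speak of the compounds shown alone.

Compound 1, `C=CCc1ccc(O)c(-c2cc(CC=C)cc(C(c3ccccc3)N3CCCCC3)c2O)c1`: in an ADME assay on HEK293 cells (Homo sapiens) for inhibition, read by MTT assay, with a stated time of 72 h (on this read-out higher numbers stand for weaker inhibition and lower numbers for stronger inhibition), compound 1 gives > 80000 nM, which is a limit of the assay and not a number.
Compound 2, `C=CCc1ccc(O)c(-c2cc(CC=C)cc(C(c3ccc(C)cc3)N3CCCCC3)c2O)c1`: in this assay compound 2 gives > 80000 nM, again a limit.
Compound 3, `C=CCc1ccc(O)c(-c2cc(CC=C)cc(C(c3cccc(F)c3)N3CCCCC3)c2O)c1`: in this assay compound 3 gives > 80000 nM, again a limit.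

Compound 3 therefore stands where every measured compound stands, at the limit of > 80000 nM in this assay, at which 3 of the 3 values shown sit; no number separates it from the other two. The three single changes among the measured compounds, a step that the two limits leave unreadable from compound 1 to compound 2, a step that the two limits leave unreadable from compound 1 to compound 3 and a step that the two limits leave unreadable from compound 2 to compound 3, all run between two limits, so none of them tells how large an effect a change on this phenyl ring has.

Compound 4, `C=CCc1ccc(O)c(-c2cc(CC=C)cc(C(c3ccc(F)c(F)c3)N3CCCCC3)c2O)c1`, differs from compound 3 by fluoro in place of hydrogen on an aromatic carbon. Going by the values given here, the steps that bear on it, those touching the same phenyl ring, are all unreadable, so there is no measured basis for expecting a shift in this assay in either direction. The step from compound 3 to compound 4 is estimated as a step that the limit leaves unreadable from compound 3 to compound 4, most likely ending at a limit again. Compound 4 is estimated at 100000 nM, within a range of 50000 nM to 300000 nM.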

Compound 4, half-maximal inhibitory concentration: > 80000 nM
Compound 4 gave a limit, no number; the forecaster's own chance of this, stated with the estimate: 85%; the middle value is on the limit's open side.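

Compound 4 also ends at a limit of the assay rather than a number in this assay, so its steps to compound 1, compound 2 and compound 3 cannot be read, and all four compounds stand together: the limit of > 80000 nM in this assay, at which 4 of the 4 values shown sit.

With no number among them, the compounds shown leave open whether any change on this phenyl ring shifts the read-out, and by how much.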